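A few compounds are considered here, and "the series" means these few. Any claim that something is new, unique, unknown or untested is made for them only; others in the source may bear on it.

In an ADME assay on Vero cells (Chlorocebus sabaeus) for cytotoxicity, read by MTT assay, tested at 100 uM (a lower number here means a stronger effect, a higher number a weaker effect of the compound at the concentration tested), compound 1 `CCOC(=O)C(C(=O)c1ccc(OC)cc1)C(NC(C)=O)c1ccc(C(C)C)cc1` gives 90.4% and compound 2 `CCOC(=O)C(C(=O)c1ccc(OC)cc1)C(NC(C)=O)c1ccc(OC)c(OC)c1` gives 88.5%. Compound 2 has the lower of the two numbers, yet the step of a number 1.9 percentage points lower from compound 1 to compound 2 (within the scatter) lies within the scatter, so the two values cannot be told apart. Compound 3 `CCOC(=O)C(C(=O)c1ccc(OC)cc1)C(NC(C)=O)c1cc(OC)ccc1Br` differs from compound 2 only in the group on that chain carbon: 2-bromo-5-methoxyphenyl in place of 3,4-dimethoxyphenyl on a saturated chain carbon bound to an amide-type nitrogen and a saturated chain carbon. Going by the values given here, the only comparable step swaps the same group, and it stayed within the scatter, so no step beyond the scatter is expected here either, giving a number 0.5 percentage points lower from compound 2 to compound 3 (within the scatter). Compound 3 is therefore estimated at 88%, somewhere between 77% and 97%.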

Compound 3, a percentage reported as activity, at one concentration (the size of the read-out at that concentration, not a potency): 90.7%
Compound 3: middle estimate off by 2.7 percentage points, on the low side; the range from low to high includes it.
By their numbers in this assay, from the lowest: compounds 2, 1 and 3 (each within the scatter of the next).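

On the saturated chain carbon bound to an amide-type nitrogen and a saturated chain carbon, even a group carrying bromine, 2-bromo-5-methoxyphenyl, leaves the result in this assay unchanged against 3,4-dimethoxyphenyl (a number 2.2 percentage points higher from compound 2 to compound 3 (within the scatter)) and against 4-isopropylphenyl (a number 0.3 percentage points higher from compound 1 to compound 3 (within the scatter)). These three differently substituted phenyl groups therefore cannot be told apart at this position. No available evidence bears on this result. Still open, from the compounds shown here alone, is whether this position stays just as indifferent when it carries something other than a substituted phenyl ring, such as an amine or a carboxylic acid.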